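From a Butyl Chain to a 3-Methoxyphenyl Group

This account rests on a few compounds, and the source may have more. Where it says the series, first, only, none or still open, it means among the compounds named here.

In a functional assay on T47D cells (Homo sapiens) for antiproliferative activity, read by MTT assay, with a stated time of 72 h (on this read-out higher numbers stand for weaker inhibition and lower numbers for stronger inhibition), compound 1 `CCCCn1ccnc1-c1cc(OC)c(OC)c(OC)c1` gives > 100000 nM as its reading, which is a limit of the assay and not a number. Compound 2 `COc1ccc(-n2ccnc2-c2cc(OC)c(OC)c(OC)c2)cc1[N+](=O)[O-]` gives 10000 nM as a measured number in this assay and carries a ring on that same nitrogen. Compound 3 `COc1cccc(-n2ccnc2-c2cc(OC)c(OC)c(OC)c2)c1` has 3-methoxyphenyl in place of butyl on an aromatic nitrogen of the shared core. Among the compounds with values here, with the ring of compound 2 at 10000 nM as the only guide, a clear move toward stronger inhibition is expected, an at least 5.0-fold lower number from compound 1 to compound 3 (0.69 log units; beyond the scatter) by this rough estimate. For compound 3 the expected value is 20000 nM with an estimated range from 4000 nM to 100000 nM in this assay.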

Compound 3, half-maximal inhibitory concentration: 32200 nM
Estimate against measurement, compound 3: 1.6-fold (0.21 log units) below; measured number inside the range.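

On the aromatic nitrogen of the shared core, 3-methoxyphenyl in place of butyl gives an at least 3.1-fold lower number from compound 1 to compound 3 (0.49 log units; beyond the scatter) in this assay, so a change at this position can move the reading beyond the scatter. Compound 2 alone could not show this, as it differs from compound 1 in more than one place. On these data alone, the true size of the step stays unknown because compound 1 sits at a limit of the assay: the limit of > 100000 nM in this assay, at which 1 of the 3 values shown sits.

As far as these compounds go, it remains open whether the ring itself or its methoxy group carries the step. A plain phenyl, a benzyl group or a longer chain on this nitrogen could separate these.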